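Working notes: methoxy to chloro step in the series

The compounds below may be only part of what the source reports. "The series", "measured", "known", "first", "only" and "open" are said of these compounds alone.

Of the compounds shown here, two have been measured in an assay on isolated protein for inhibition of Maltase-glucoamylase (Homo sapiens), with stated times of 15 min and 10 min, tested at 64 uM; a lower number here means less inhibition, a higher number more inhibition at the concentration tested (going by the name of the read-out). Compound 1 `C=CCc1cc(CN(C)c2ccccc2)c(O)c(-c2cc(CC=C)c(O)c(CN(C)c3ccccc3)c2)c1` gives 63% in this assay. Compound 2 `C=CCc1cc(-c2ccc(O)c(CC=C)c2)c(O)c(C(c2ccc(OC)cc2)N2CCCCC2)c1` gives 85%, the higher of the two numbers, with compound 1 lower by a gap beyond the usual scatter.

Compound 3 `C=CCc1cc(-c2ccc(O)c(CC=C)c2)c(O)c(C(c2ccc(Cl)cc2)N2CCCCC2)c1` differs from compound 2 in one place only: chloro in place of methoxy on an aromatic carbon. For the measured compounds named here, no measured pair shows this change, so no step size can be read from the data. The expected step from compound 2 to compound 3 is a number 5 percentage points lower from compound 2 to compound 3 (within the scatter), which is judged to stay within the scatter, with no clear direction. Compound 3 is therefore estimated at 80% in this assay, with a range from 60% to 95%.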

Compound 3, a percentage reported as inhibition, at one concentration (the size of the read-out at that concentration, not a potency): 45%
The estimate for compound 3 lay 35 percentage points above the measured number, outside the stated range (below it).
By their numbers in this assay, from the lowest: compound 3; then compound 1; then compound 2.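

For the compounds shown here, the change from 4-methoxyphenyl to 4-chlorophenyl gives the first single-place step: in this assay it reads a number 40 percentage points lower from compound 2 to compound 3 (beyond the scatter) and counts as large. Inhibition at this position therefore depends on the group on the aromatic carbon, and methoxy and chloro are not interchangeable there. No available measurement explains the size of this step.

As far as these compounds go, it remains open whether the drop reflects the loss of methoxy or the arrival of chloro. An ethoxy group, a hydroxy group or an amine at the same aromatic carbon would help to separate these two readings.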